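Phenyl for pyridin-2-yl on a second hydroxyphenyl core

This account rests on a few compounds, and the source may have more. Where it says the series, first, only, none or still open, it means among the compounds named here.

Compound 1 `Oc1ccc(-c2cc(-c3ccccn3)nc(-c3ccccc3Cl)c2)cc1` gives 5.2% in an assay on isolated protein for inhibition of DNA topoisomerase 1 (Homo sapiens), with a stated time of 30 min, tested at 100 uM; a lower number here means a weaker effect, a higher number a stronger effect of the compound at the concentration tested. Compound 2 `Oc1ccc(-c2cc(-c3ccccc3)nc(-c3ccccc3Cl)c2)cc1` gives 13.6% in this assay. The difference between these two, (phenyl in place of pyridin-2-yl on an aromatic carbon), went with a step of a number 8.4 percentage points higher from compound 1 to compound 2 (within the scatter). Compound 3 `Oc1cccc(-c2cc(-c3ccccn3)nc(-c3ccccc3Cl)c2)c1` gives 0% in this assay; its core differs from that of compound 1 by 3-hydroxyphenyl in place of 4-hydroxyphenyl on an aromatic carbon, a change that gave a number 5.2 percentage points lower from compound 1 to compound 3 (within the scatter). Compound 4 `Oc1cccc(-c2cc(-c3ccccc3)nc(-c3ccccc3Cl)c2)c1` has not yet been measured in this assay. It differs from compound 3 by phenyl in place of pyridin-2-yl on an aromatic carbon. For the measured compounds named here, this is the same kind of change as the one from compound 1 to compound 2, not the same change: in compound 1 the place is meta to a 4-hydroxyphenyl group, whereas in compound 3 it is meta to a 3-hydroxyphenyl group. For compound 4 a step of a number 6 percentage points higher from compound 3 to compound 4 (within the scatter) is expected, set beside the earlier step of a number 8.4 percentage points higher from compound 1 to compound 2 (within the scatter), because the same kind of change gave a number 8.4 percentage points higher from compound 1 to compound 2 (within the scatter) on the other core, a move that stayed within the usual scatter. Compound 4 is accordingly estimated at 6%, with a likely range from 0% to 18%.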

Compound 4, a percentage reported as inhibition, at one concentration (the size of the read-out at that concentration, not a potency): 3.2%
The estimate for compound 4 lay 2.8 percentage points above the measured number; low and high end bracket the measured number.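

In this assay, phenyl in place of pyridin-2-yl gave a number 3.2 percentage points higher from compound 3 to compound 4 (within the scatter), and this step does not differ from the earlier one on the other core: the same change on two cores in this assay, a number 8.4 percentage points higher (within the scatter) from compound 1 to compound 2 and a number 3.2 percentage points higher (within the scatter) from compound 3 to compound 4, 5.2 percentage points apart, within the scatter of two such steps The hydroxyphenyl change, 3-hydroxyphenyl in place of 4-hydroxyphenyl, gave a number 10.4 percentage points lower from compound 2 to compound 4 (beyond the scatter), and it too agrees with its earlier counterpart: the same change on two cores in this assay, a number 5.2 percentage points lower (within the scatter) from compound 1 to compound 3 and a number 10.4 percentage points lower (beyond the scatter) from compound 2 to compound 4, 5.2 percentage points apart, within the scatter of two such steps This shows that, across these four compounds, neither change behaved measurably differently on one core than on the other, but it does not show that the phenyl change has any effect of its own, since both of its steps lie within the scatter, and a read-out at one concentration gives no potency.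

On these data alone, whether an amine or a carboxylic acid in place of the hydroxy group would shift the read-out remains open. So does whether the phenyl change would carry over to a core lacking the 2-chlorophenyl group.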